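Removal of the hydroxymethyl group on the aryl triazole

The source may report more compounds than this note shows. Statements on the series, on what has been measured and on what is new or still open speak of the compounds shown alone.

Measured so far in a functional assay on MCF7 cells (Homo sapiens) for antiproliferative activity, read by MTT assay, with a stated time of 48 h; on this read-out higher numbers stand for weaker inhibition and lower numbers for stronger inhibition:
compound 1 `COc1cc(/C=C/C(C)=O)ccc1OCc1cn(-c2ccccc2CO)nn1` gives 65800 nM
compound 2 `COc1cccc(-n2cc(COc3ccc(/C=C/C(C)=O)cc3OC)nn2)c1` gives 1800 nM
compound 3 `COc1cc(/C=C/C(C)=O)ccc1OCc1cn(-c2ccc(C=O)cc2)nn1` gives 86400 nM

Compound 1 stands second highest of the three numbers; its nearest neighbour is compound 3, with a 1.3-fold higher number from compound 1 to compound 3 (0.12 log units; within the scatter), while compound 2 lies furthest away, with a 37-fold lower number from compound 1 to compound 2 (1.56 log units; beyond the scatter).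

Compound 4 `COc1cc(/C=C/C(C)=O)ccc1OCc1cn(-c2ccccc2)nn1` is not yet measured. It differs from compound 1 in one place: hydrogen in place of hydroxymethyl on an aromatic carbon. The change sits on an aromatic carbon of the six-membered aromatic ring of carbon only, ortho to a large group.

For the measured compounds named here, none of the measured steps removes a group to leave hydrogen; each swaps one substituted aryl for another. The step from the 2-(hydroxymethyl)phenyl to the 4-formylphenyl compound, a 1.3-fold higher number from compound 1 to compound 3 (0.12 log units; within the scatter), shows that one substituent swap leaves this assay essentially unchanged, whereas a 37-fold lower number from compound 1 to compound 2 (1.56 log units; beyond the scatter) shows that a 3-methoxyphenyl brings a large drop. Compound 2 against compound 3, a 48-fold higher number from compound 2 to compound 3 (1.68 log units; beyond the scatter), confirms that the aryl substituent can matter greatly. Going by the values given here, there is no direct precedent, so the uncertainty is wide. For compound 4 the expected step is a 2.2-fold lower number from compound 1 to compound 4 (0.34 log units; beyond the scatter).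

For compound 4 the expected value in this assay is 30000 nM, with a range from 8000 nM to 110000 nM.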

Compound 4, half-maximal inhibitory concentration: > 100000 nM
Compound 4: only a limit was reported (the forecaster's own chance of this, stated with the estimate: 10%); at least 3.3-fold (0.52 log units) between middle value and limit.
By their numbers in this assay, from the lowest: compound 2; then compounds 1 and 3 (each within the scatter of the next). At a limit, above all of these: compound 4.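

In this assay compound 4 gives > 100000 nM, which is a limit and not a number, and this is the only compound shown with no substituent on the phenyl attached to the triazole, and the only one at that limit: the limit of > 100000 nM in this assay, at which 1 of the 4 values shown sits. Hydrogen in place of hydroxymethyl gives an at least 1.5-fold higher number from compound 1 to compound 4 (0.18 log units; that floor lies within the scatter), and hydrogen in place of formyl gives an at least 1.1-fold higher number from compound 3 to compound 4 (0.06 log units; that floor lies within the scatter), so the removal shows no sign of a gain, though neither floor separates the compounds beyond the scatter. Hydrogen in place of methoxy gives an at least 55-fold higher number from compound 2 to compound 4 (1.74 log units; beyond the scatter), which shows that the lower number of the 3-methoxyphenyl compound is lost with the methoxy group and does not come from the bare phenyl.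

As far as these compounds go, how far the true number of compound 4 lies past its limit stays open, so the size of the hydroxymethyl step has only a floor. Also open, from the compounds shown here alone, is whether an aminomethyl group, a carboxylic acid or a longer hydroxyalkyl chain on the same aromatic carbon would move the number toward that of compound 2.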